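The source may report more compounds than this note shows. Statements on the series, on what has been measured and on what is new or still open speak of the compounds shown alone.

Working notes on the series. The shared core of compound 1 `Cc1cc2ncn(CCCCN3CCN(C(c4ccccc4)c4ccccc4)CC3)c2cc1C` carries a head group on a saturated chain carbon, four bonds along the chain from an amine nitrogen in a ring. In an assay on RPMI-8226 cells for antagonist activity at P2X purinoceptor 7 (Homo sapiens), read by calcium flux (a lower number here means a stronger inhibitor, a higher number a weaker inhibitor), compound 1 gives 770 nM. Going by the values given here, compound 2 `N#Cc1ccc2c(ccn2CCCCN2CCN(C(c3ccccc3)c3ccccc3)CC2)c1` has the 5-cyano-1H-indol-1-yl head and in this assay compound 2 gives 3800 nM; it stands as the higher of the two numbers so far, the only measured step being a 4.9-fold higher number from compound 1 to compound 2 (0.69 log units; beyond the scatter). Compound 3 `c1ccc(-c2nnnn2CCCCN2CCN(C(c3ccccc3)c3ccccc3)CC2)cc1` is the next member: 5-phenyl-1H-tetrazol-1-yl in place of 5-cyano-1H-indol-1-yl on a saturated chain carbon, four bonds along the chain from an amine nitrogen in a ring. Among the compounds with values here, the one step that bears on it is the head-group swap from compound 1 to compound 2, which moved the number beyond the scatter; a swap of the same kind at the same place is therefore expected to move the number again, but the direction for the tetrazole head is not fixed by either of the measured compounds. For compound 3 the expected step is a 1.3-fold lower number from compound 2 to compound 3 (0.10 log units; within the scatter), and for compound 3 the estimate in this assay is 3000 nM, with a range from 800 nM to 12000 nM.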

Compound 3, half-maximal inhibitory concentration: 3200 nM
Compound 3: middle estimate off by 1.1-fold (0.03 log units), on the low side; the range from low to high includes it.
By their numbers in this assay, from the lowest: compound 1; then compounds 3 and 2 (each within the scatter of the next).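

In this assay, at this place on a saturated chain carbon, four bonds along the chain from an amine nitrogen in a ring, the 5-phenyl-1H-tetrazol-1-yl and 5-cyano-1H-indol-1-yl heads cannot be told apart, with a 1.2-fold lower number from compound 2 to compound 3 (0.07 log units; within the scatter), even though the entering head holds more ring hetero atoms and lacks the triple bond. Set against the 5,6-dimethyl-1H-benzimidazol-1-yl head, the tetrazole head gives a 4.2-fold higher number from compound 1 to compound 3 (0.62 log units; beyond the scatter), so compound 1 is now the strongest inhibitor of the three, and two heads of different make-up both stand beyond the scatter from it. No measurement at hand gives a reason for either step.

The compounds shown leave open whether the edge of compound 1 rests on its two methyl groups or on the rest of its head, a question that an unsubstituted 1H-benzimidazol-1-yl head would address directly. They also leave open whether the phenyl of compound 3 can take a substituent such as a carboxylic acid or an amine, and how any of these heads behaves on a longer chain.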